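Ring Size on the Amide Nitrogen and Cell Toxicity

The compounds below may be only part of what the source reports. "The series", "measured", "known", "first", "only" and "open" are said of these compounds alone.

Compound 1 `CC(C)(C)C(=O)N(CCCCCCN1C[C@H](O)[C@@H](O)[C@H](O)[C@H]1CO)c1ccc(F)cc1F` and compound 2 `CC(C)(C)C(=O)N(CCCCCCN1C[C@H](O)[C@@H](O)[C@H](O)[C@H]1CO)C1CCCC1` share one core and differ only on an amide-type nitrogen. In an ADME assay on BHK cells (Mesocricetus auratus) for cytotoxicity, read by MTT assay (on this read-out lower numbers stand for higher toxicity in this test and higher numbers for lower toxicity in this test), compound 1 sits at the assay limit of > 500000 nM. In this assay compound 2 likewise sits at the limit of > 500000 nM. The step that the two limits leave unreadable from compound 1 to compound 2 is unreadable, since both values rest on (the limit of > 500000 nM in this assay, at which 2 of the 2 values shown sit). Compound 3 `CC(C)(C)C(=O)N(CCCCCCN1C[C@H](O)[C@@H](O)[C@H](O)[C@H]1CO)C1CCCCCC1` carries cycloheptyl in place of cyclopentyl on an amide-type nitrogen. For the measured compounds named here, no measured step reads this change. Compound 3 is therefore expected to remain at the limit, with an estimated 500000 nM (range 250000 nM to 1000000 nM). The step of a number no higher from compound 2 to compound 3 (the limit leaves the size open) is expected to show nothing beyond the scatter.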

Compound 3, half-maximal cytotoxic concentration: > 500000 nM
Compound 3: no number, only a limit; the forecaster's own chance of this, stated with the estimate: 85%; the middle value lies on the limit itself.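

No step can be read among compound 1, compound 2 and compound 3 in this assay, since all three rest on a limit of the assay: the limit of > 500000 nM in this assay, at which 3 of the 3 values shown sit.

The compounds shown leave open whether the group on the amide-type nitrogen affects the read-out at all.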